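Cytotoxicity notes: from compound 2 to compound 3

A few compounds are considered here, and "the series" means these few. Any claim that something is new, unique, unknown or untested is made for them only; others in the source may bear on it.

For the measured compounds named here, in an ADME assay on HEK293 cells (Homo sapiens) for cytotoxicity, read by resazurin assay, with a stated time of 16 h (on this read-out higher numbers stand for an effect only at larger amounts of compound and lower numbers for an effect already at smaller amounts), compound 2 (`COc1cc(/C=C/C(=O)CC(=O)/C=C/c2ccc(O)cc2)ccc1OC(=O)c1ccccc1`) gives 370000 nM as the only number so far. Compound 1 (`COc1cc(/C=C/C(=O)CC(=O)/C=C/c2ccc(OC(=O)c3ccccc3)cc2)ccc1O`) stands at > 500000 nM as a limit of this assay and not a number. Compound 3 (`O=C(/C=C/c1ccc(O)cc1)CC(=O)/C=C/c1ccc(OC(=O)c2ccccc2)cc1`) carries hydrogen in place of methoxy on an aromatic carbon, ortho to a benzoyloxy group (hydrogen in place of methoxy on an aromatic carbon). Going by the values given here, no measured step covers this change, so no step beyond the scatter is expected in this assay in either direction. The estimated step of a 1.0-fold higher number from compound 2 to compound 3 (0.01 log units; within the scatter) is expected to stay small. Compound 3 is estimated at 380000 nM (expected range 170000 nM to 800000 nM).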

Compound 3, half-maximal effective concentration: 270000 nM
Compound 3: middle estimate off by 1.4-fold (0.15 log units), on the high side; the range from low to high includes it.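

In this assay, the series now has a measured step for hydrogen in place of methoxy on an aromatic carbon, ortho to a benzoyloxy group: a 1.4-fold lower number from compound 2 to compound 3 (0.14 log units; within the scatter), so the methoxy makes no difference beyond the scatter at this position. The same replacement read from the other benzoyl arrangement gives an at least 1.8-fold lower number from compound 1 to compound 3 (0.26 log units; that floor lies within the scatter). That floor rests on a limit and not on a number: the limit of > 500000 nM in this assay, at which 1 of the 3 values shown sits.

As far as these compounds go, whether an amine or a longer chain such as ethoxy on this carbon would move the number beyond the scatter remains open.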